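The source may report more compounds than this note shows. Statements on the series, on what has been measured and on what is new or still open speak of the compounds shown alone.

Compound 1, `CCC(COc1cccc(C(F)(F)F)c1)OC(=O)NCc1ccccc1`: in an assay for inhibition of zeta-carotene desaturase, chloroplastic/chromoplastic (Capsicum annuum), using a Dixon plot, with a stated time of 8 h (a higher number here means a weaker inhibitor, a lower number a stronger inhibitor), compound 1 gives > 100000 nM, a limit of the assay.
Compound 2, `CCC(COc1cccc(C(F)(F)F)c1)OC(=O)NCc1ccccc1Cl`: in this assay compound 2 gives > 100000 nM, a limit of the assay.
Compound 3, `CCC(COC(=O)NCc1ccccc1)Oc1cccc(C(F)(F)F)c1`: in this assay compound 3 gives > 100000 nM, a limit of the assay.

Compound 3 thus stands only at a limit in this assay, as do the two others, all three sitting at the limit of > 100000 nM in this assay, at which 3 of the 3 values shown sit. Among the measured compounds shown here, the single measured step, a step that the two limits leave unreadable from compound 1 to compound 2, runs from one limit to another and its size cannot be read; it concerns a chloro change on an aromatic carbon, not the chain carbon altered here. Compound 4, `O=C(NCc1ccccc1)OCCOc1cccc(C(F)(F)F)c1`, differs from compound 3 by hydrogen in place of ethyl on a saturated chain carbon bound to an oxygen on an aromatic ring and a saturated chain carbon. For the measured compounds named here, no measured step bears on this change, so no direction can be read from the numbers; the expectation is that compound 4 remains at the limit. Compound 4 is estimated at 150000 nM, with a range from 30000 nM to 1000000 nM. The step from compound 3 to compound 4 is expected to be a step that the limit leaves unreadable from compound 3 to compound 4.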

Compound 4, half-maximal inhibitory concentration: > 100000 nM
Compound 4 was reported as a limit; the forecaster's own chance of this, stated with the estimate: 85%; the middle value lies beyond the limit too.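

Compound 4 stands at a limit of the assay, as do compound 1 and compound 3, so neither step into compound 4 can be read: the limit of > 100000 nM in this assay, at which 4 of the 4 values shown sit. The compounds shown leave open whether hydrogen in place of ethyl, or the chloro change, shifts the inhibition in this assay at all.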